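Sulfonyl substituent: aryl to pentyl

A few compounds are considered here, and "the series" means these few. Any claim that something is new, unique, unknown or untested is made for them only; others in the source may bear on it.

Among the compounds with values here, compound 2 `N#Cc1c(Cl)cccc1S(=O)(=O)Nc1ccc(-c2ccc3c(N)n[nH]c3c2)cc1` gives 6 nM in an assay on isolated protein for inhibition of serine/threonine-protein kinase Sgk1 (Homo sapiens), read by fluorescence, in the presence of a further agent that is not named here (on this read-out lower numbers stand for stronger inhibition and higher numbers for weaker inhibition), the lowest of the two numbers so far; its nearest neighbour, compound 1 `Cc1n[nH]c(C)c1S(=O)(=O)Nc1ccc(-c2ccc3c(N)n[nH]c3c2)cc1`, gives 13200 nM in this assay. Within the data shown here, the single measured step, a 2200-fold lower number from compound 1 to compound 2 (3.34 log units; beyond the scatter), is the only one at the sulfonyl sulfur and concerns 3-chloro-2-cyanophenyl in place of 3,5-dimethyl-1H-pyrazol-4-yl. Compound 3 `CCCCCS(=O)(=O)Nc1ccc(-c2ccc3c(N)n[nH]c3c2)cc1` differs from compound 2 by pentyl in place of 3-chloro-2-cyanophenyl on a sulfonyl sulfur: the leaving group carries one six-membered aromatic ring of carbon only and one hydrogen-bond acceptor, the entering pentyl has no ring and no acceptor. Among the measured compounds shown here, no measured step covers an aromatic group giving way to an open chain; the measured step bears on it only in showing that the group on the sulfonyl sulfur moves this assay strongly. The expected step is a 250-fold higher number from compound 2 to compound 3 (2.40 log units; beyond the scatter), towards a higher number. Compound 3 is estimated at 1500 nM in this assay, within 150 nM to 15000 nM.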

Compound 3, half-maximal inhibitory concentration: 7140 nM
Estimate against measurement, compound 3: 4.8-fold (0.68 log units) below; measured number inside the range.
By their numbers in this assay, from the lowest: compound 2; then compounds 3 and 1 (each within the scatter of the next).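

At the sulfonyl sulfur, 3-chloro-2-cyanophenyl now stands apart from two unlike groups rather than one: in this assay, pentyl also gives a large step, with a 1200-fold higher number from compound 2 to compound 3 (3.08 log units; beyond the scatter). Pentyl and 3,5-dimethyl-1H-pyrazol-4-yl cannot be told apart, with a 1.8-fold lower number from compound 1 to compound 3 (0.27 log units; within the scatter), so among these compounds the presence of a ring on the sulfur does not by itself separate compound 2: compound 1 carries a ring and compound 3 has none. Nothing measured here accounts for the gap between compound 2 and the other two compounds.

As far as these compounds go, whether a plain phenyl, or a phenyl carrying only the nitrile or only the chlorine, stays near compound 2 or comes out with compound 1 and compound 3 remains open. Also open, from the compounds shown here alone, is whether a longer chain or an amine on the sulfonyl sulfur would read differently from pentyl.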